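Swapping the Oxane for a Furylmethyl Arm

A few compounds are considered here, and "the series" means these few. Any claim that something is new, unique, unknown or untested is made for them only; others in the source may bear on it.

Measured compounds:
compound 1, `N=c1c2c(-c3ccccc3)cn(Cc3ccccc3)c2ncn1C1CCOCC1`: 0.0867 h
compound 2, `Cc1c(C)n(Cc2ccccc2)c2ncn([C@H]3CC[C@H](O)CC3)c(=N)c12`: 2 h

In an ADME assay on microsomes from liver (Mus musculus, strain CD1) for metabolic stability, read by LC-MS, using NADPH, with a stated time of 60 min (a higher number here means that the compound lasts longer, a lower number that the compound disappears faster), compound 1 gives 0.0867 h, which is the lower of the two numbers recorded; compound 2, at 2 h, sits far above it, and the gap lies beyond the usual scatter. Compound 1 therefore stands as the compound that disappears fastest among those measured.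

The next compound, compound 3, `N=c1c2c(-c3ccccc3)cn(Cc3ccccc3)c2ncn1Cc1ccco1`, keeps the core of compound 1 and changes it in one place: (furan-2-yl)methyl in place of oxan-4-yl on an aromatic nitrogen. The change thus exchanges one group for another of the same count of heavy atoms and with the same single hydrogen-bond acceptor, but an aromatic five-membered ring replaces a saturated six-membered one, and a single carbon now links it to the ring nitrogen.

For the measured compounds named here, no measured pair shows this change, so no step can be read for it. Compound 3 is expected to remain near compound 1, with a step of a 1.2-fold lower number from compound 1 to compound 3 (0.09 log units; within the scatter) that is at most modest and more likely downward than upward. The estimate for compound 3 in this assay is 0.07 h, within a range from 0.025 h to 0.2 h.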

Compound 3, half-life: 0.05 h
The estimate for compound 3 lay 1.4-fold (0.15 log units) above the measured number; low and high end bracket the measured number.
By their numbers in this assay, from the lowest: compounds 3 and 1 (each within the scatter of the next); then compound 2.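

With compound 3, this position gives its first readable step: on the aromatic nitrogen, placing (furan-2-yl)methyl in place of oxan-4-yl gives, in this assay, a 1.7-fold lower number from compound 1 to compound 3 (0.24 log units; within the scatter). The exchange replaces one six-membered non-aromatic ring with a five-membered aromatic ring and adds a single carbon link, yet the step stays within the scatter, so this pair does not separate the two groups in this assay. Nothing available explains the result or ties it to any property of either group.

Because the ring and the link change together in this one step, the pair cannot show what each contributes, and oxan-4-ylmethyl or furan-3-yl on the same nitrogen would pull those two changes apart. Also open, on these data alone, is how the number responds at this position to groups of another kind, such as an amine, a carboxylic acid or a longer chain, on the core of compound 1.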